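Nitro for chloro on compound 1: working notes

A few compounds are considered here, and "the series" means these few. Any claim that something is new, unique, unknown or untested is made for them only; others in the source may bear on it.

Compound 1 `Cc1cc(NC(=O)Cn2cc(-c3ccc(Cl)cc3)nn2)no1` gives 1910 nM in a functional assay on BMDM cells (Mus musculus, strain C57BL/6) for inhibition, with a stated time of 2 days (a higher number here means a weaker inhibitor, a lower number a stronger inhibitor), which is the highest of the two numbers recorded so far; its nearest neighbour is compound 2 `Cc1csc(NC(=O)Cn2cc(-c3ccc(Cl)cc3)nn2)n1`, which gives 520 nM. The step of a 3.7-fold lower number from compound 1 to compound 2 (0.57 log units; beyond the scatter) comes from 4-methyl-1,3-thiazol-2-yl in place of 5-methyl-1,2-oxazol-3-yl on an amide-type nitrogen. Compound 3 `Cc1cc(NC(=O)Cn2cc(-c3ccccc3Cl)nn2)no1` returns only a limit, > 30000 nM, in this assay. That limit, (the limit of > 30000 nM in this assay, at which 1 of the 3 values shown sits), is what the step of an at least 15-fold higher number from compound 1 to compound 3 (1.19 log units; beyond the scatter) rests on, and it follows 2-chlorophenyl in place of 4-chlorophenyl on an aromatic carbon.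

Compound 4 `Cc1cc(NC(=O)Cn2cc(-c3ccc([N+](=O)[O-])cc3)nn2)no1` differs from compound 1 by nitro in place of chloro on an aromatic carbon. Of the measured steps, an at least 15-fold higher number from compound 1 to compound 3 (1.19 log units; beyond the scatter) is the only one that touches the chlorophenyl, and it moved the chloro rather than swapping it; a 3.7-fold lower number from compound 1 to compound 2 (0.57 log units; beyond the scatter) concerns the other end of the molecule. Neither step replaces the group para to the large group with another group, so the size of the effect of nitro in place of chloro is not anchored by any measured pair. A step of modest size at most is therefore expected, with the direction left open, and compound 4 is estimated at 3000 nM in this assay, within 800 nM to 12000 nM, which corresponds to an expected 1.6-fold higher number from compound 1 to compound 4 (0.20 log units; within the scatter).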

Compound 4, half-maximal inhibitory concentration: 1220 nM
For compound 4 the middle estimate is 2.5-fold (0.39 log units) above the measured one, within the range that was stated.
By their numbers in this assay, from the lowest: compound 2; then compounds 4 and 1 (each within the scatter of the next). At a limit, above all of these: compound 3.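

In this assay the replacement gives a 1.6-fold lower number from compound 1 to compound 4 (0.19 log units; within the scatter) and so compound 1 and compound 4 cannot be told apart, although nitro brings 3 heavy atoms and 2 hydrogen-bond acceptors where chloro brings 1 heavy atom and 0 hydrogen-bond acceptors. The earlier compounds shown here showed only what happens when the chloro leaves this place on the ring, as an at least 15-fold higher number from compound 1 to compound 3 (1.19 log units; beyond the scatter) rests on a limit of the assay, whereas this pair shows that a second group, on the same aromatic carbon para to a large group, reads like chloro. The compounds shown hold nothing that bears on why nitro and chloro read alike here.

On these data alone, whether an amine, a carboxylic acid or a methoxy group on this carbon would also read like chloro stays open, and two groups are too few to define what this position accepts. Also open, as far as these compounds go, is whether nitro in place of chloro reads the same with 4-methyl-1,3-thiazol-2-yl on the amide-type nitrogen, the setting in which compound 2 gives 520 nM as the chloro member.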